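The source may report more compounds than this note shows. Statements on the series, on what has been measured and on what is new or still open speak of the compounds shown alone.

Of the compounds shown here, three built on one shared core have been measured in an ADME assay on HEK-293T cells (Homo sapiens) for inhibition, read by CCK-8 assay, with a stated time of 48 h, tested at 20 uM; on this read-out higher numbers stand for more inhibition of growth at the one concentration tested and lower numbers for less inhibition of growth. Compound 1 `Cc1ccc(S(=O)(=O)Oc2ccccc2/C=C(\C#N)C(=O)Nc2nnc(Cc3ccccc3)s2)cc1` gives 15%. Compound 2 `COc1ccc(S(=O)(=O)Oc2ccccc2/C=C(\C#N)C(=O)Nc2nnc(Cc3ccccc3)s2)cc1` differs from compound 1 by methoxy in place of methyl on an aromatic carbon and in this assay compound 2 gives 23%, a step of a number 8 percentage points higher from compound 1 to compound 2 (within the scatter). Compound 3 `Cc1ccc(S(=O)(=O)Oc2ccccc2/C=C(\C#N)C(=O)Nc2nnc(Cc3ccc(F)cc3)s2)cc1` differs from compound 1 at the other end of the molecule, by fluoro in place of hydrogen on an aromatic carbon, and in this assay compound 3 gives 16%, a step of a number 1 percentage points higher from compound 1 to compound 3 (within the scatter). The three numbers lie close together, and none of the steps between them is large enough to stand out from the scatter of repeated measurements.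

Compound 4 `COc1ccc(S(=O)(=O)Oc2ccccc2/C=C(\C#N)C(=O)Nc2nnc(Cc3ccc(F)cc3)s2)cc1` has not yet been measured. It carries the core of compound 3 and differs from compound 3 by methoxy in place of methyl on an aromatic carbon. For the measured compounds named here, this is the same change as the one from compound 1 to compound 2, made here on the core of compound 3, whose difference from the core of compound 1 is the one already described. Going by the values given here, the expected step is a number 8 percentage points higher from compound 3 to compound 4 (within the scatter), set beside the earlier step of a number 8 percentage points higher from compound 1 to compound 2 (within the scatter), which is the only guide available. That guide is itself within the scatter, so the direction of the expected step is not secure. Compound 4 is therefore estimated to give 24% in this assay, with a range from 12% to 36%.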

Compound 4, percent growth inhibition at one concentration: 20%
Compound 4: the middle estimate sits 4 percentage points above what was measured; measured number inside the range.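

In this assay, methoxy in place of methyl on the core that carries fluoro gives a step of a number 4 percentage points higher from compound 3 to compound 4 (within the scatter), and fluoro in place of hydrogen on the core that carries methoxy gives a step of a number 3 percentage points lower from compound 2 to compound 4 (within the scatter). The methoxy change gives no sign of depending on the core it is made on: the same change on two cores in this assay, a number 8 percentage points higher (within the scatter) from compound 1 to compound 2 and a number 4 percentage points higher (within the scatter) from compound 3 to compound 4, 4 percentage points apart, within the scatter of two such steps. The fluoro change likewise gives no sign of depending on its core, but with every step here inside the scatter, this does not show that either change really shifts growth inhibition, nor that the two changes would combine in the same way on other cores: the same change on two cores in this assay, a number 1 percentage points higher (within the scatter) from compound 1 to compound 3 and a number 3 percentage points lower (within the scatter) from compound 2 to compound 4, 4 percentage points apart, within the scatter of two such steps.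

The compounds shown leave open whether a group of a different kind in place of the methyl or methoxy, such as an amine, a carboxylic acid or a longer chain, would give a step that stands clear of the scatter. They also leave open whether chloro or trifluoromethyl in place of the fluoro would do so, and how any of these compounds would behave at a concentration other than the one tested.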